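Series notes: replacing the fluoro substituent and cytotoxicity

The source may hold more compounds than are shown below. What is called first, only, known or untested is meant among the compounds shown, and "the series" means these compounds.

In an ADME assay on MDBK cells (Bos taurus) for cytotoxicity, read by MTT assay, with a stated time of 96 h (a higher number here means that more compound is tolerated, a lower number that less compound is tolerated), compound 3 `Fc1ccc(-c2nc3cc(C(F)(F)F)ccc3[nH]2)cc1` gives 19000 nM, the highest of the two numbers in hand. Compound 1 `O=[N+]([O-])c1ccc(-c2nc3cc(C(F)(F)F)ccc3[nH]2)cc1` gives 6000 nM in this assay. Compound 2 `COc1ccc(-c2nc3cc(C(F)(F)F)ccc3[nH]2)cc1` reaches only a limit of the assay, > 100000 nM in this assay, which is not a number. Compound 4 `O=C(CN1CCCC1)Nc1ccc(-c2nc3cc(C(F)(F)F)ccc3[nH]2)cc1` differs from compound 3 at one place: (((pyrrolidin-1-yl)methyl)carbonyl)amino in place of fluoro on an aromatic carbon. Within the data shown here, two measured steps touch that position. a 3.2-fold higher number from compound 1 to compound 3 (0.50 log units; beyond the scatter), while an at least 5.2-fold lower number from compound 2 to compound 3 (0.72 log units; beyond the scatter); both lie beyond the scatter, and one of the three values sits at the limit of > 100000 nM in this assay, at which 1 of the 3 values shown sits. Among the measured compounds shown here, no measured step carries the entering group, so the expectation rests only on the observation that every change at this position so far has moved the number beyond the scatter, and that the one larger substituent gave the most tolerated compound. The step of a 2.1-fold higher number from compound 3 to compound 4 (0.32 log units; beyond the scatter) is therefore expected to be a modest rise in the tolerated concentration, with a fair chance that only a limit is returned. Compound 4 is expected to give 40000 nM in this assay, within 12000 nM to 100000 nM.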

Compound 4, half-maximal cytotoxic concentration: 15000 nM
Compound 4: middle estimate off by 2.7-fold (0.43 log units), on the high side; the measured number falls inside the stated range.
By their numbers in this assay, from the lowest: compound 1; then compounds 4 and 3 (each within the scatter of the next). At a limit, above all of these: compound 2.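

The (((pyrrolidin-1-yl)methyl)carbonyl)amino group does not separate from fluoro in this assay: a 1.3-fold lower number from compound 3 to compound 4 (0.10 log units; within the scatter). Among these compounds, this is the only change at this position so far that stays within the scatter, even though the entering group is much larger than the one it replaces. It does separate from nitro, with a 2.5-fold higher number from compound 1 to compound 4 (0.40 log units; beyond the scatter), and the comparison with methoxy, an at least 6.6-fold lower number from compound 2 to compound 4 (0.82 log units; beyond the scatter), has one bound only, as compound 2 stands at a limit: the limit of > 100000 nM in this assay, at which 1 of the 4 values shown sits.

From the compounds shown here alone, it remains open which part of the entering group matters, the pyrrolidine ring, the amide hydrogen or the chain; a piperidine, a morpholine or a plain acetylamino group at this place would separate these parts. Going by these compounds, how far compound 2 stands from the others also remains open.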